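The source may hold more compounds than are shown below. What is called first, only, known or untested is meant among the compounds shown, and "the series" means these compounds.

Of the compounds shown here, two sharing one core have been measured in a functional assay on HEK293 cells for agonist activity at Glucose-dependent insulinotropic receptor (Homo sapiens), read by cAMP accumulation, with a stated time of 60 min; on this read-out lower numbers stand for an effect already at smaller amounts and higher numbers for an effect only at larger amounts of compound. Compound 1 `CCCc1cnc(N2CCC(C3Cc4c(ccc(C5=CCN(S(=O)(=O)CCC)CC5)c4F)O3)CC2)nc1` gives 5 nM. Compound 2 `CCCc1cnc(N2CCC(C3Cc4cc(C5=CCN(S(=O)(=O)CCC)CC5)cc(F)c4O3)CC2)nc1` gives 62 nM, the higher of the two numbers, and compound 1 stands well below it, beyond the scatter. Compound 3 `CCCc1cnc(N2CCC(C3Cc4c(F)c(C5=CCN(S(=O)(=O)CCC)CC5)cc(F)c4O3)CC2)nc1` has not yet been measured. It differs from compound 2 by fluoro in place of hydrogen on an aromatic carbon, the entering fluoro sitting ortho to the fused ring and ortho to the large group, para to the fluoro group already present. Among the measured compounds shown here, no measured pair shows a step of this kind, so the data leave its direction open. Compound 2 sits at 62 nM, and a modest move toward a lower number seems plausible. The step of a 1.8-fold lower number from compound 2 to compound 3 (0.25 log units; within the scatter) is expected to lie close to the edge of the scatter. Compound 3 is therefore estimated at 35 nM, with a range from 9 nM to 130 nM.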

Compound 3, half-maximal effective concentration: 2 nM
Compound 3: middle estimate off by 18-fold (1.24 log units), on the high side; measured number outside the range, below it.
By their numbers in this assay, from the lowest: compound 3; then compound 1; then compound 2.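

In this assay, among the compounds shown here, fluoro in place of hydrogen on the aromatic carbon ortho to the large group and para to the fluoro group gives a 31-fold lower number from compound 2 to compound 3 (1.49 log units; beyond the scatter), so this one carbon carries a large change in the number, which the earlier compounds could not show as a single step. Compound 1 already carries fluoro at this carbon, and fluoro in place of hydrogen at another aromatic carbon gives a 2.5-fold lower number from compound 1 to compound 3 (0.40 log units; beyond the scatter), so compound 3, with both fluoro groups, has the lowest number of the three. No measurement at hand accounts for either step.

Going by these compounds, whether chloro, methyl or methoxy at this carbon would lower the number as fluoro does stays open. So does whether the step holds with a longer chain in place of the propyl on the sulfonyl group.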